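A few compounds are considered here, and "the series" means these few. Any claim that something is new, unique, unknown or untested is made for them only; others in the source may bear on it.

Compound 2 `O=C(CCCC1CCN(Cc2ccccc2Br)CC1)c1ncco1` is the bromo analogue of compound 1 `O=C(CCCC1CCN(Cc2ccccc2)CC1)c1ncco1`. In an assay on isolated protein for inhibition of Fatty-acid amide hydrolase 1 (Homo sapiens) (a higher number here means a weaker inhibitor, a lower number a stronger inhibitor), compound 1 gives 315 nM, and in this assay compound 2 gives 315 nM; the step of no change at the digits printed from compound 1 to compound 2 (within the scatter) shows that adding bromo to the benzyl ring left the inhibition where it was, so compound 2 stands level with compound 1 on the numbers shown. Compound 3 `O=C(CCCC1CCN(Cc2ccc(Br)cc2)CC1)c1ncco1` differs from compound 2 by 4-bromophenyl in place of 2-bromophenyl on a saturated chain carbon bound to an amine nitrogen in a ring. For the measured compounds named here, no measured step moves the bromine from one ring carbon to another; the only step that bears on it at all is the addition of bromo from compound 1 to compound 2, which was within the scatter. As far as these compounds go, on that basis one expects no step beyond the scatter in this assay, though the position change itself is untested. The step of a 1.1-fold lower number from compound 2 to compound 3 (0.02 log units; within the scatter) is therefore estimated to be small. Compound 3 is expected to give about 300 nM, within a range of 100 nM to 900 nM.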

Compound 3, half-maximal inhibitory concentration: 45 nM
Compound 3: middle estimate off by 6.7-fold (0.82 log units), on the high side, and the stated range ends above it.
By their numbers in this assay, from the lowest: compound 3; then compounds 1 and 2 (each within the scatter of the next).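

In this assay the place of the bromine on the benzyl ring proves to matter, since 4-bromophenyl in place of 2-bromophenyl gives a 7.0-fold lower number from compound 2 to compound 3 (0.85 log units; beyond the scatter) with the same atoms joined differently. The earlier flat result of adding bromo therefore held only for 2-bromophenyl, for as 4-bromophenyl the same addition gives a 7.0-fold lower number from compound 1 to compound 3 (0.85 log units; beyond the scatter) and not no change at the digits printed from compound 1 to compound 2 (within the scatter) as seen before. Nothing shown here gives a measured reason why the place of the bromine counts this much.

The compounds shown leave open whether the lower number belongs to bromine itself or would hold with a chlorine or a methoxy group in place of the bromine of the 4-bromophenyl group. They also leave open whether it would survive a longer chain in the shared core.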